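Amine substituent series: ethyl to isopropyl step

A few compounds are considered here, and "the series" means these few. Any claim that something is new, unique, unknown or untested is made for them only; others in the source may bear on it.

Compound 3 `CCN(C[C@H]1Cc2c(cccc2N2CCNCC2)CN1)[C@H]1CCCc2cccnc21` gives 14.8 nM in a functional assay on CCRF-CEM cells for antagonist activity at C-X-C chemokine receptor type 4 (Homo sapiens), read by calcium flux, with stated times of 25 min and 90 s (on this read-out higher numbers stand for weaker inhibition and lower numbers for stronger inhibition), the lowest of the three numbers in hand. Compound 1 `c1cnc2c(c1)CCC[C@@H]2N(CC1CC1)C[C@H]1Cc2c(cccc2N2CCNCC2)CN1` gives 26.7 nM, and the step of a 1.8-fold lower number from compound 1 to compound 3 (0.26 log units; within the scatter) lies within the scatter, so the two stand together. Compound 2 `FC1(F)CCC(CN(C[C@H]2Cc3c(cccc3N3CCNCC3)CN2)[C@H]2CCCc3cccnc32)CC1` gives 498 nM; the step of a 34-fold lower number from compound 2 to compound 3 (1.53 log units; beyond the scatter) is the one large movement in the set, and a 19-fold higher number from compound 1 to compound 2 (1.27 log units; beyond the scatter) shows the same movement from the other side.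

Compound 4 `CC(C)N(C[C@H]1Cc2c(cccc2N2CCNCC2)CN1)[C@H]1CCCc2cccnc21` carries methyl in place of hydrogen on a saturated chain carbon bound to an amine nitrogen and a saturated chain carbon. Going by the values given here, the steps that bear on this are the two just named: exchanging cyclopropyl for methyl on the same carbon moved nothing beyond the scatter, whereas the 4,4-difluorocyclohexyl group cost a great deal. The change to compound 4 resembles the first of these far more than the second, since what enters is a single carbon without a ring. Compound 4 is therefore expected to move little, with the estimated step of a 1.4-fold higher number from compound 3 to compound 4 (0.13 log units; within the scatter) inside the scatter and without a preferred direction. For compound 4 the estimate in this assay is 20 nM, in the range 8 nM to 60 nM.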

Compound 4, half-maximal inhibitory concentration: 364 nM
The estimate for compound 4 lay 18-fold (1.26 log units) below the measured number; the measured number lies above the stated range.
By their numbers in this assay, from the lowest: compounds 3 and 1 (each within the scatter of the next); then compounds 4 and 2 (each within the scatter of the next).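

In this assay, the hydrogen on the saturated chain carbon bound to the amine nitrogen stays in place in compounds 1, 2 and 3, and replacing it with methyl, the ethyl to isopropyl change, gives a 25-fold higher number from compound 3 to compound 4 (1.39 log units; beyond the scatter). So this position is far more sensitive to a single added methyl than the swap of cyclopropyl for methyl on the same carbon suggested, as a 14-fold higher number from compound 1 to compound 4 (1.13 log units; beyond the scatter) confirms, and the size of the entering group alone does not set the outcome here: with a 1.4-fold lower number from compound 2 to compound 4 (0.14 log units; within the scatter), the small isopropyl and the much larger (4,4-difluorocyclohexyl)methyl stand together. No measurement in hand speaks to what lies behind this loss.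

Still open, on these data alone, is whether the loss follows any replacement of that hydrogen, which a cyclopentyl or tert-butyl group on the amine nitrogen would help to test. As far as these compounds go, it is equally open whether an unbranched longer chain such as n-propyl or n-butyl stays with compounds 1 and 3, which would show if the large steps seen here depend on substitution at that carbon.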